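Swapping a thiophene for a benzene on the ketone

A few compounds are considered here, and "the series" means these few. Any claim that something is new, unique, unknown or untested is made for them only; others in the source may bear on it.

Two chalcone-like compounds sharing one core have been tested in a functional assay on MCF7 cells (Homo sapiens) for inhibition, read by sulforhodamine B assay, with a stated time of 72 h; on this read-out higher numbers stand for weaker inhibition and lower numbers for stronger inhibition. Compound 1, `O=C(/C=C/c1cn(-c2ccccc2)nc1-c1cccnc1)c1ccccc1`, carries a phenyl ketone and gives 4100 nM in this assay. Compound 2, `O=C(/C=C/c1cn(-c2ccccc2)nc1-c1ccncc1)c1ccsc1`, carries a thiophen-3-yl ketone and a differently placed ring nitrogen, and gives 1500 nM in this assay. Compound 2 thus stands at the lower of the two numbers, with the number for compound 1 lying beyond the usual scatter above it; since the two compounds differ in more than one place, their values alone show this, and no single change can be credited for it.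

Compound 3, `O=C(/C=C/c1cn(-c2ccccc2)nc1-c1ccncc1)c1ccccc1`, is the next compound. It differs from compound 2 in one place: phenyl in place of thiophen-3-yl on a carbonyl carbon. Going by the values given here, no pair among the measured compounds isolates this change, so there is no measured step to lean on. The expectation is a small move, toward a somewhat higher number, and not clearly beyond the scatter; the step from compound 2 to compound 3 is expected to be about a 1.7-fold higher number from compound 2 to compound 3 (0.22 log units; within the scatter) in this assay. Compound 3 is therefore expected to give roughly 2500 nM in this assay, with the estimate reasonably ranging from 900 nM to 7000 nM.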

Compound 3, half-maximal inhibitory concentration: 3400 nM
For compound 3 the middle estimate is 1.4-fold (0.13 log units) below the measured one; low and high end bracket the measured number.
By their numbers in this assay, from the lowest: compound 2; then compounds 3 and 1 (each within the scatter of the next).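

In this assay, the swap at this position now has a measured size of its own: with the rest of the molecule unchanged, phenyl in place of thiophen-3-yl on a carbonyl carbon gives a step beyond the scatter (a 2.3-fold higher number from compound 2 to compound 3 (0.36 log units; beyond the scatter)). Going by these compounds alone, the other single change, pyridin-4-yl in place of pyridin-3-yl on an aromatic carbon, stays within the scatter (a 1.2-fold lower number from compound 1 to compound 3 (0.08 log units; within the scatter)), so of the two changes now isolated, only the one on the carbonyl carbon moves the number by more than repeated measurements would. Nothing measured here explains why the thiophen-3-yl ketone and the benzoyl compound differ.

The compounds shown leave open whether the same swap gives a similar step when pyridin-3-yl is present instead of pyridin-4-yl, since this rests on a single pair. They also leave open how other groups on the carbonyl carbon, such as thiophen-2-yl, furan-3-yl, cyclohexyl, or a phenyl ring carrying a methoxy group or an amine, would compare with compound 2 and compound 3.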